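Notes on compound 3 and the untested compound 4

The source may hold more compounds than are shown below. What is called first, only, known or untested is meant among the compounds shown, and "the series" means these compounds.

Measured so far in a functional assay on HCT-116 cells (Homo sapiens) for antiproliferative activity, read by MTT assay, with a stated time of 48 h; on this read-out higher numbers stand for weaker inhibition and lower numbers for stronger inhibition:
compound 1 `N#CC1=C(N)Oc2c(c3nc4ccccc4nc3c3ccccc23)C12C(=O)N(Cc1cnnn1-c1ccc(Cl)cc1)c1ccccc12`: > 50000 nM, a limit
compound 2 `N#CC1=C(N)Oc2c(c3nc4ccccc4nc3c3ccccc23)C12C(=O)N(Cc1cnnn1-c1ccc([N+](=O)[O-])cc1)c1ccccc12`: > 50000 nM, a limit
compound 3 `N#CC1=C(N)Oc2c(N)cc3nc4ccccc4nc3c2C12C(=O)N(Cc1cnnn1-c1ccccc1Br)c1ccccc12`: 12400 nM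

Compound 1 and compound 2 both sit at the limit of > 50000 nM in this assay, at which 2 of the 3 values shown sit, so each of them is a limit and not a number. Among the measured compounds shown here, the one change between them, a step that the two limits leave unreadable from compound 1 to compound 2, cannot be read. The two limits hide its size. For the measured compounds named here, compound 3 therefore stands as the only number in this assay within this set; the other two values give no comparison against it.

Compound 4 `Cc1ccc(C)c(-n2nncc2CN2C(=O)C3(C(C#N)=C(N)Oc4c(N)cc5nc6ccccc6nc5c43)c3ccccc32)c1` differs from compound 3 in one place: 2,5-dimethylphenyl in place of 2-bromophenyl on an aromatic nitrogen. Both compound 3 and compound 4 carry the same amino group on the shared core; only the aryl group on the aromatic nitrogen is exchanged. Going by the values given here, no measured step touches this position with a readable size, and the single step on record, a step that the two limits leave unreadable from compound 1 to compound 2, concerns another position and is unreadable anyway. There is thus no evidence that the exchange of 2-bromophenyl for 2,5-dimethylphenyl should move the number beyond the scatter in either direction.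

The expectation for compound 4 in this assay is therefore set close to compound 3, at 15000 nM with a range from 4000 nM to 50000 nM; the estimated step of a 1.2-fold higher number from compound 3 to compound 4 (0.08 log units; within the scatter) is one of no meaningful size.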

Compound 4, half-maximal inhibitory concentration: > 50000 nM
Compound 4: only a limit was reported; the forecaster's own chance of this, stated with the estimate: 25%; at least 3.3-fold (0.52 log units) between middle value and limit.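

In this assay, among the compounds shown here, the exchange of 2-bromophenyl for 2,5-dimethylphenyl on the aromatic nitrogen gives the only readable step in the set: an at least 4.0-fold higher number from compound 3 to compound 4 (0.60 log units; beyond the scatter). Compound 4 gives > 50000 nM, which is a limit and not a number, so this step has a lower bound but no upper one. The earlier compounds offered no readable step at any position, whereas this pair shows that the aryl group on this nitrogen is not a neutral place for change on the shared core, and compound 3 remains the only compound with a number: the limit of > 50000 nM in this assay, at which 3 of the 4 values shown sit.

Which part of the exchange carries the step stays open, as the bromine leaves and two methyl groups enter together, and a plain phenyl or a pyridyl group on this nitrogen would be needed to separate these parts. The step between the two other limit compounds cannot be read, and the compounds shown therefore say nothing about whether any aryl group on this nitrogen gives a number lower than that of compound 3.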